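Swapping the aryl substituent on the shared core

A few compounds are considered here, and "the series" means these few. Any claim that something is new, unique, unknown or untested is made for them only; others in the source may bear on it.

Compound 2 `COc1cc2c(Oc3ccc(NC(=O)c4nn(-c5ccccc5Br)c(=O)c5ccccc45)cc3F)ccnc2cc1OCCCN1CCC(C)CC1`, measured in a functional assay on MDA-MB-231 cells (Homo sapiens) for cytotoxicity, read by MTT assay, with a stated time of 72 h (a lower number here means a stronger inhibitor, a higher number a weaker inhibitor), gives 1240 nM, the highest of the two numbers gathered so far; its nearest neighbour is compound 1 `COc1cc2c(Oc3ccc(NC(=O)c4nn(-c5ccc(Br)cc5)c(=O)c5ccccc45)cc3F)ccnc2cc1OCCCN1CCC(C)CC1`, which in this assay gives 1160 nM, and the step of a 1.1-fold higher number from compound 1 to compound 2 (0.03 log units; within the scatter) lies within the scatter. Compound 3 `COc1cc2c(Oc3ccc(NC(=O)c4nn(-c5ccc([N+](=O)[O-])cc5)c(=O)c5ccccc45)cc3F)ccnc2cc1OCCCN1CCC(C)CC1` has not yet been measured. It differs from compound 2 in one place: 4-nitrophenyl in place of 2-bromophenyl on an aromatic nitrogen. Among the compounds with values here, only the step from compound 1 to compound 2 bears on this change, and it shows that moving the bromine around the ring left the read-out essentially unchanged. Within the data shown here, no measured step speaks to a nitro group in this position, so a step of no size beyond the scatter is expected for a 1.0-fold lower number from compound 2 to compound 3 (0.01 log units; within the scatter). For compound 3 the estimate in this assay is 1200 nM, with a range from 500 nM to 3000 nM.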

Compound 3, half-maximal inhibitory concentration: 4010 nM
Compound 3: middle estimate off by 3.3-fold (0.52 log units), on the low side; measured number outside the range, above it.
By their numbers in this assay, from the lowest: compounds 1 and 2 (each within the scatter of the next); then compound 3.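

In this assay, the group on the aromatic nitrogen proves able to shift the read-out, which the two bromophenyl compounds had not shown: replacing 2-bromophenyl with 4-nitrophenyl gives a 3.2-fold higher number from compound 2 to compound 3 (0.51 log units; beyond the scatter), a modest loss of inhibition. The comparison with 4-bromophenyl isolates the group on the aromatic carbon, as nitro in place of bromo gives a 3.5-fold higher number from compound 1 to compound 3 (0.54 log units; beyond the scatter), so the loss does not depend on comparing across different bromine positions. Nothing available explains why nitro gives the weaker result.

The compounds shown leave open whether the loss is specific to nitro or would also appear with an amine, a methoxy group or a carboxylic acid on the same phenyl ring. They also leave open whether 2-nitrophenyl would match 4-nitrophenyl, as the two bromophenyl compounds matched each other within the scatter.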